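The compounds below may be only part of what the source reports. "The series", "measured", "known", "first", "only" and "open" are said of these compounds alone.

- compound 1 `C=CC(=O)Nc1cc(Nc2ncc(I)c(Nc3ccccc3S(=O)(=O)N(C)C)n2)c(OC)cc1N(C)CCN(C)C` gives 12%
- compound 2 `C=CC(=O)Nc1cc(Nc2ncc(F)c(Nc3ccccc3S(=O)(=O)N(C)C)n2)c(OC)cc1N(C)CCN(C)C` gives 10%
- compound 3 `C=CC(=O)Nc1cc(Nc2ncc(Cl)c(Nc3ccccc3S(=O)(=O)C(C)C)n2)c(OC)cc1N(C)CCN(C)C` gives 12%

The read-out here is an ADME assay on microsomes from liver (Mus musculus) for metabolic stability, read by LC-MS, using NADPH, with a stated time of 30 min, tested at 1 uM; on this read-out lower numbers stand for a less stable compound and higher numbers for a more stable compound. Compound 3 stands at 12%, within the usual scatter of both other compounds. Compound 4 `C=CC(=O)Nc1cc(Nc2ncc(Cl)c(Nc3ccccc3S(=O)(=O)N(C)C)n2)c(OC)cc1N(C)CCN(C)C` differs from it by one change, dimethylamino in place of isopropyl on a sulfonyl sulfur. Among the compounds with values here, no measured step makes this exact change. Within the data shown here, the one measured step, a number 2 percentage points lower from compound 1 to compound 2 (within the scatter), swaps fluoro for iodo on an aromatic carbon and stays within the scatter. Compound 1 and compound 2 already carry dimethylamino on the sulfonyl sulfur, and their values show no gap from compound 3 beyond the scatter. The expected step is therefore small, a number 1 percentage points lower from compound 3 to compound 4 (within the scatter), with no direction beyond the scatter. For compound 4 the estimated value is 11%, with an expected range from 5% to 20%.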

Compound 4, percent of the compound remaining: 23%
Compound 4: middle estimate off by 12 percentage points, on the low side; measured number outside the range, above it.
By their numbers in this assay, from the lowest: compounds 2, 1 and 3 (each within the scatter of the next); then compound 4.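

In this assay, within the data shown here, dimethylamino in place of isopropyl on a sulfonyl sulfur gives a number 11 percentage points higher from compound 3 to compound 4 (beyond the scatter), the first evidence that this position can shift the result beyond the scatter. With dimethylamino held fixed, the halogen on the aromatic carbon also counts: chloro gives a number 13 percentage points higher from compound 2 to compound 4 (beyond the scatter) and a number 11 percentage points higher from compound 1 to compound 4 (beyond the scatter), whereas fluoro and iodo differ only by a number 2 percentage points lower from compound 1 to compound 2 (within the scatter). Nothing shown explains these differences. Still open, from the compounds shown here alone, is how a morpholine or a methyl on the sulfonyl sulfur would compare, or a bromo on the aromatic carbon.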